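From piperazin-1-yl to 4-aminopiperidin-1-yl on compound 1

The source may report more compounds than this note shows. Statements on the series, on what has been measured and on what is new or still open speak of the compounds shown alone.

Within the data shown here, in a functional assay on a cell-free system (plasma, Homo sapiens) for inhibition, with Plasma (Rattus norvegicus) as the target (on this read-out lower numbers stand for stronger inhibition and higher numbers for weaker inhibition), compound 1 `Cc1c(OCc2cccnc2)ccc2c(N3CCNCC3)cc(=O)oc12` gives 980 nM, the lowest number of the three compounds measured so far. Compound 2 `CCCCOc1ccc2c(N3CCNCC3)cc(=O)oc2c1C` gives 2790 nM, and compound 3 `Cc1c(OCC2CCCN(C)C2)ccc2c(N3CCNCC3)cc(=O)oc12` gives 4700 nM.

Compound 4 `Cc1c(OCc2cccnc2)ccc2c(N3CCC(N)CC3)cc(=O)oc12` differs from compound 1 in one place, with 4-aminopiperidin-1-yl in place of piperazin-1-yl on an aromatic carbon.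

Among the measured compounds shown here, no measured step touches that place, so the evidence is only indirect. All three steps alter the group on a saturated chain carbon bound to an oxygen: a 2.8-fold higher number from compound 1 to compound 2 (0.45 log units; beyond the scatter), a 4.8-fold higher number from compound 1 to compound 3 (0.68 log units; beyond the scatter) and a 1.7-fold higher number from compound 2 to compound 3 (0.23 log units; within the scatter). The first two are modest and the last lies within the scatter. For the measured compounds named here, with no measured replacement of piperazin-1-yl to draw on, no step clearly beyond the scatter is expected in this assay, and a slightly higher number is only weakly favoured, as compound 1 stands lowest. The expected change is a 1.5-fold higher number from compound 1 to compound 4 (0.18 log units; within the scatter). Compound 4 is estimated at 1500 nM, within an expected range from 400 nM to 5000 nM.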

Compound 4, half-maximal inhibitory concentration: 156000 nM
Beside the measured number, compound 4's estimate is 100-fold (2.02 log units) below it; the measured number lies above the stated range.
By their numbers in this assay, from the lowest: compound 1; then compounds 2 and 3 (each within the scatter of the next); then compound 4.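

In this assay, the group opposite the ring oxygen proves far more sensitive than the group on the ether side chain: 4-aminopiperidin-1-yl in place of piperazin-1-yl gives a 160-fold higher number from compound 1 to compound 4 (2.20 log units; beyond the scatter), whereas the largest earlier step was a 4.8-fold higher number from compound 1 to compound 3 (0.68 log units; beyond the scatter). This large change comes from a swap that leaves the counts of hydrogen-bond donors and acceptors and the net charge as they were, so those counts do not separate the two groups. No supporting measurement is available to explain the loss.

The compounds shown hold only one replacement at this position, on a single pyridin-3-yl ether, so it remains open whether the same step would appear with the butyl ether of compound 2. From the compounds shown here alone, it is also open whether a 4-methylpiperazin-1-yl or an unsubstituted piperidin-1-yl would read close to compound 1 or to compound 4.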